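The source may report more compounds than this note shows. Statements on the series, on what has been measured and on what is new or still open speak of the compounds shown alone.

Two measured compounds share one core. Compound 1 `COc1cc(OC)c(/C=C/S(=O)(=O)Cc2ccc(F)c(N)c2)c(OC)c1` bears a free amino group and a fluorine on the aromatic ring that carries the nitrogen, whereas compound 2 `COC(=O)C(F)(F)Nc1cc(CS(=O)(=O)/C=C/c2c(OC)cc(OC)cc2OC)ccc1OC` bears on that nitrogen a difluoro(methoxycarbonyl)methyl group and a methoxy group on the ring. In a functional assay on DU-145 cells (Homo sapiens) for cytotoxicity, read by trypan blue exclusion, with a stated time of 96 h (on this read-out lower numbers stand for stronger inhibition and higher numbers for weaker inhibition), compound 1 gives 2500 nM. In this assay compound 2 gives 250 nM, the lowest of the two numbers, and its gap to compound 1 lies beyond the usual scatter, so compound 2 is the more potent of the pair.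

Compound 3 `COc1cc(OC)c(/C=C/S(=O)(=O)Cc2ccc(OC)c(NC(C)(C)C(=O)O)c2)c(OC)c1` has not yet been measured. It departs from compound 2 in one place: 1-carboxy-1-methylethyl in place of difluoro(methoxycarbonyl)methyl on a nitrogen on an aromatic ring. Among the measured compounds shown here, no measured pair shows this same change, so its effect in this assay cannot be read from the data and must be estimated. Compound 3 is expected to lose some potency against compound 2, with a step of a 3.2-fold higher number from compound 2 to compound 3 (0.51 log units; beyond the scatter) of moderate size toward higher numbers, though one that could also fall within the scatter. Compound 3 is therefore estimated at 800 nM, within a range from 250 nM to 2500 nM.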

Compound 3, half-maximal inhibitory concentration: 150 nM
Beside the measured number, compound 3's estimate is 5.3-fold (0.73 log units) above it; the measured number lies below the stated range.
By their numbers in this assay, from the lowest: compounds 3 and 2 (each within the scatter of the next); then compound 1.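

Among the compounds shown here, the swap of difluoro(methoxycarbonyl)methyl for 1-carboxy-1-methylethyl on a nitrogen on an aromatic ring gives the first step in this assay that can be read at a single place, and it comes to a 1.7-fold lower number from compound 2 to compound 3 (0.22 log units; within the scatter). This position therefore accepts the exchange of one group for the other with no change that this assay can separate from the scatter, even though the fluorine atoms leave, the entering group has 1 hydrogen-bond donor where the leaving group has 0 hydrogen-bond donors, and the heavy-atom count goes from 7 to 6. Nothing available on these compounds bears on why the two groups read alike.

For the compounds shown here, the single step cannot show how the parts of either group contribute, since the fluorine atoms, the methyl groups and the ester or acid end all change together. Open as well is how this assay would read a free amine with the methoxy group kept on the ring, a methyl ester of the 1-carboxy-1-methylethyl group, or a longer chain ending in a carboxylic acid on that nitrogen.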